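The compounds below may be only part of what the source reports. "The series", "measured", "known", "first", "only" and "open" are said of these compounds alone.

Compound 1 `Cc1c(C(=O)N/N=C\c2ccccc2)oc2cccc(O)c12` gives 29200 nM in a functional assay on PC-3 cells (Homo sapiens) for inhibition; a higher number here means a weaker inhibitor, a lower number a stronger inhibitor. Among the measured compounds shown here, compound 2 `Cc1c(C(=O)N/N=C\c2cc(F)ccc2O)oc2cccc(O)c12` gives 3170 nM in this assay, the lowest of the two numbers so far; the only measured step, a 9.2-fold lower number from compound 1 to compound 2 (0.96 log units; beyond the scatter), concerns a different change. For the measured compounds named here, compound 3 `Cc1c(C(=O)N/N=C\c2cc(Cl)ccc2O)oc2cccc(O)c12` differs from compound 2 by chloro in place of fluoro on an aromatic carbon, a halogen exchange that no measured pair covers. With nothing bearing directly on it, the step of a 1.1-fold lower number from compound 2 to compound 3 (0.02 log units; within the scatter) is expected to stay within the scatter. Compound 3 is therefore estimated at 3000 nM in this assay, with a range of 1000 nM to 9000 nM.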

Compound 3, half-maximal inhibitory concentration: 3120 nM
Estimate against measurement, compound 3: 1.0-fold (0.02 log units) below; the range from low to high includes it.
By their numbers in this assay, from the lowest: compounds 3 and 2 (each within the scatter of the next); then compound 1.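

In this assay, chloro in place of fluoro on this aromatic carbon, para to the hydroxy group, gives no readable change (a 1.0-fold lower number from compound 2 to compound 3 (0.01 log units; within the scatter)), so the two halogens cannot be told apart at this position. The step from phenyl seen with 5-fluoro-2-hydroxyphenyl also holds for 5-chloro-2-hydroxyphenyl (a 9.4-fold lower number from compound 1 to compound 3 (0.97 log units; beyond the scatter)). No evidence bears on this result. Open, on these data alone, is whether an amine or a carboxylic acid at this position would hold the number. Also open, as far as these compounds go, is how that step from phenyl divides between the hydroxy group and the halogen.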